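A Phenyl Swap Repeated on a Fluorinated Core

The source may hold more compounds than are shown below. What is called first, only, known or untested is meant among the compounds shown, and "the series" means these compounds.

Compound 1 `Cc1cc(=O)n(-c2ccccc2OC(F)(F)F)nc1C(=O)Nc1ccc(Oc2ncnc3ccsc23)cc1` gives 10100 nM in a functional assay on A549 cells (Homo sapiens) for cytotoxicity, read by MTT assay, with a stated time of 72 h; a higher number here means a weaker inhibitor, a lower number a stronger inhibitor. Compound 2 `Cc1cc(=O)n(-c2cccc(F)c2)nc1C(=O)Nc1ccc(Oc2ncnc3ccsc23)cc1` gives 9540 nM in this assay; it differs from compound 1 by 3-fluorophenyl in place of 2-(trifluoromethoxy)phenyl on an aromatic nitrogen, and the step is a 1.1-fold lower number from compound 1 to compound 2 (0.02 log units; within the scatter). Compound 3 `Cc1cc(=O)n(-c2ccccc2OC(F)(F)F)nc1C(=O)Nc1ccc(Oc2ncnc3ccsc23)c(F)c1` gives 5720 nM in this assay. Its core differs from that of compound 1 by fluoro in place of hydrogen on an aromatic carbon, a step of a 1.8-fold lower number from compound 1 to compound 3 (0.25 log units; within the scatter). Compound 4 `Cc1cc(=O)n(-c2cccc(F)c2)nc1C(=O)Nc1ccc(Oc2ncnc3ccsc23)c(F)c1` has not been measured. It differs from compound 3 by 3-fluorophenyl in place of 2-(trifluoromethoxy)phenyl on an aromatic nitrogen, the same change as that from compound 1 to compound 2, here made on the core of compound 3. Because a 1.1-fold lower number from compound 1 to compound 2 (0.02 log units; within the scatter) lay within the scatter, the step of a 1.1-fold lower number from compound 3 to compound 4 (0.03 log units; within the scatter) is expected to be equally small in this assay. Compound 4 is therefore estimated at 5400 nM, with a likely range from 2500 nM to 12000 nM.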

Compound 4, half-maximal inhibitory concentration: 5220 nM
Compound 4: the middle estimate sits 1.0-fold (0.01 log units) above what was measured; the measured number falls inside the stated range.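

In this assay, the phenyl swap made on the fluorinated core gave a 1.1-fold lower number from compound 3 to compound 4 (0.04 log units; within the scatter), and it matched the same swap on the core of compound 1: the same change on two cores in this assay, a 1.1-fold lower number (0.02 log units; within the scatter) from compound 1 to compound 2 and a 1.1-fold lower number (0.04 log units; within the scatter) from compound 3 to compound 4, 1.0-fold (0.01 log units) apart, within the scatter of two such steps. The fluoro change, read on the cores bearing 3-fluorophenyl, gave a 1.8-fold lower number from compound 2 to compound 4 (0.26 log units; within the scatter), and it also repeated: the same change on two cores in this assay, a 1.8-fold lower number (0.25 log units; within the scatter) from compound 1 to compound 3 and a 1.8-fold lower number (0.26 log units; within the scatter) from compound 2 to compound 4, 1.0-fold (0.01 log units) apart, within the scatter of two such steps. Both changes therefore carried between these two cores without a detectable difference, yet every step lies within the scatter, so the data do not show that either change alters the number at all.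

The compounds shown leave open whether these steps would hold with an amine or a carboxylic acid on the phenyl ring at the aromatic nitrogen. They also leave open whether any change in this series can produce a step beyond the scatter in this assay.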